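A few compounds are considered here, and "the series" means these few. Any claim that something is new, unique, unknown or untested is made for them only; others in the source may bear on it.

Of the compounds shown here, two built on the shared core have been measured in a physicochemical assay for solubility, read by HPLC, at pH 7.4; a higher number here means a more soluble compound, a lower number a less soluble compound. Compound 1 (`CCCCCOCc1[nH]c2ccc([N+](=O)[O-])cc2c(=O)c1C(=O)OCC`) gives 15000 nM, and compound 2 (`CCCCCCCc1[nH]c2ccc([N+](=O)[O-])cc2c(=O)c1C(=O)O`) gives 15000 nM. Compound 2 therefore stands level with compound 1, its nearest neighbour on the numbers, and the two lie within the usual scatter of each other. Within the data shown here, no measured pair differs in a single place, so the data hold no direct measure of what one structural exchange does in this assay.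

Compound 3 (`CCCCCOCc1[nH]c2ccc([N+](=O)[O-])cc2c(=O)c1C(=O)O`) is reached from compound 2 by one exchange, pentyloxy in place of hexyl on a saturated chain carbon bound to an aromatic carbon. Among the measured compounds shown here, the only guide is that the two measured compounds sit level, with compound 1 at 15000 nM and compound 2 at 15000 nM. The expected step is no change at the digits printed from compound 2 to compound 3 (within the scatter), so no shift beyond the usual scatter is expected in either direction. For compound 3 the estimated value is 15000 nM, with an expected range from 7000 nM to 35000 nM.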

Compound 3, solubility: 50000 nM
The estimate for compound 3 lay 3.3-fold (0.52 log units) below the measured number; the whole stated range lies below it.
By their numbers in this assay, from the lowest: compounds 1 and 2 (each within the scatter of the next); then compound 3.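

In this assay, pentyloxy in place of hexyl on a saturated chain carbon bound to an aromatic carbon gives a 3.3-fold higher number from compound 2 to compound 3 (0.52 log units; beyond the scatter), the first sign that this position responds to a single exchange of equal heavy-atom count, with one oxygen entering for one carbon. Hydrogen in place of ethyl on an oxygen next to a carbonyl group gives a 3.3-fold higher number from compound 1 to compound 3 (0.52 log units; beyond the scatter), so a second place also answers to a single exchange, and both steps end at compound 3, something the earlier two compounds, which differ from each other in two places, could not show. Nothing in the material at hand explains either step.

As far as these compounds go, whether the higher number at the chain position is specific to pentyloxy, or would also appear with a shorter chain, a longer ether chain or an amine in the same place, remains open. Also open, from the compounds shown here alone, is whether the step at the oxygen would hold with a different chain, such as hexyl, in place of pentyloxy, and whether a methyl group on that oxygen would read like ethyl or like hydrogen.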